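Aryl piperazine amides: from compound 3 to compound 4

The compounds below may be only part of what the source reports. "The series", "measured", "known", "first", "only" and "open" are said of these compounds alone.

Values in a functional assay on HL-60 cells (Homo sapiens) for inhibition, read by MTT assay, with a stated time of 72 h (on this read-out lower numbers stand for stronger inhibition and higher numbers for weaker inhibition), so far:
- compound 1 `C=C(C)c1ccc(N2CCN(C(=O)c3oc(C)nc3-c3ccccc3)CC2)cc1` reads "not active" (no number reported) with no number reported
- compound 2 `Cc1ccc(N2CCN(C(=O)c3oc(C)nc3-c3ccccc3)CC2)cc1` gives > 1000 nM as a limit, not a number
- compound 3 `Cc1ccc(N2CCN(C(=O)c3oc(C)nc3-c3ccccc3)CC2)c(C)c1` gives 101 nM as a number

Among the compounds with values here, compound 3 gives 101 nM as the only number so far. The other two entries carry no number. Compound 4 `Cc1nc(-c2ccccc2)c(C(=O)N2CCN(c3ccc(C(F)(F)F)cc3)CC2)o1` differs from it by 4-(trifluoromethyl)phenyl in place of 2,4-dimethylphenyl on an amine nitrogen in a ring with 4-(trifluoromethyl)phenyl in place of 2,4-dimethylphenyl on an amine nitrogen in a ring. Within the data shown here, the one measured step that bears on this is an at least 9.9-fold lower number from compound 2 to compound 3 (0.99 log units; beyond the scatter) for methyl in place of hydrogen on an aromatic carbon. That step led to the 2,4-dimethylphenyl group, which leaves again in compound 4, and neither compound 1 nor compound 2 carries that group or gives a number. The expected change is a 12-fold higher number from compound 3 to compound 4 (1.07 log units; beyond the scatter) in the direction of a higher number in this assay. For compound 4 the estimated value is 1200 nM with an expected range from 250 nM to 6000 nM and a bare limit instead of a number is a likely outcome.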

Compound 4, half-maximal inhibitory concentration: > 1000 nM
Compound 4 gave a limit, no number; the forecaster's own chance of this, stated with the estimate: 60%; the middle value is on the limit's open side.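

The change away from the 2,4-dimethylphenyl group costs activity, with an at least 9.9-fold higher number from compound 3 to compound 4 (0.99 log units; beyond the scatter). Compounds 1, 2 and 4 all lack that group and none gives a number, so among the compounds shown, a measurable value on this amine nitrogen occurs only with compound 3. The true size of the step stays unknown, and the step between the trifluoromethyl and methyl compounds cannot be read, as both ends rest on the same assay limit: the limit of > 1000 nM in this assay, at which 2 of the 4 values shown sit.

Going by these compounds, it remains open whether a phenyl ring carrying both trifluoromethyl and methyl would give a number. On these data alone, it is equally open whether a methoxy group or an amine on that phenyl ring could take the place of the methyl groups of compound 3.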